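One extra methyl on the chain of compound 2

The compounds below may be only part of what the source reports. "The series", "measured", "known", "first", "only" and "open" are said of these compounds alone.

In an ADME assay on PBMC cells (Homo sapiens) for cytotoxicity (a lower number here means that less compound is tolerated, a higher number that more compound is tolerated), compound 2 (`CCO/N=C(/c1ccc(Br)cc1)C1CCN(C(C)CCNC(=O)c2c(C)cc[n+]([O-])c2C)CC1`) gives > 177000 nM, a limit of the assay and not a number. Compound 3 (`CCO/N=C(/c1ccc(Br)cc1)C1CCN(C(C)CCN(C)C(=O)c2c(C)cc[n+]([O-])c2C)CC1`) gives > 182000 nM, also a limit. Compound 1 (`CCO/N=C(/c1ccc(Br)cc1)C1CCN(C(C)CCNC(=O)c2c(Cl)cncc2Cl)CC1`) gives a real number, 33800 nM. Compound 4 (`CCO/N=C(/c1ccc(Br)cc1)C1CCN(C(CC)CCNC(=O)c2c(C)cc[n+]([O-])c2C)CC1`) is made by one change: methyl in place of hydrogen on a saturated chain carbon, two bonds along the chain from an amine nitrogen in a ring, which turns methyl to ethyl. For the measured compounds named here, no measured step touches this place. Swapping the group on the carbonyl carbon gave an at least 5.2-fold higher number from compound 1 to compound 2 (0.71 log units; beyond the scatter). A methyl on the amide-type nitrogen gave a step that the two limits leave unreadable from compound 2 to compound 3, so that added methyl offers no readable size. Only a small shift is therefore expected, and the estimated change is a step that the limit leaves unreadable from compound 2 to compound 4. Compound 4 is expected at 180000 nM, within an estimated range of 80000 nM to 350000 nM.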

Compound 4, half-maximal cytotoxic concentration: > 177000 nM
Compound 4 ended at the assay's limit; the forecaster's own chance of this, stated with the estimate: 75%; the middle value does not contradict the limit.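

In this assay compound 2 and compound 4 both stand at a limit of the assay, and the step between them cannot be read. The compounds shown leave open whether methyl to ethyl changes the tolerated concentration at all.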